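The source may report more compounds than this note shows. Statements on the series, on what has been measured and on what is new or still open speak of the compounds shown alone.

Measured so far in a functional assay on CCRF-CEM cells (Homo sapiens) for inhibition; a lower number here means a stronger inhibitor, a higher number a weaker inhibitor:
Compound 1 `O=C1/C(=C/c2ccccc2F)Cc2ccccc21` gives 47100 nM.
Compound 2 `Cc1ccccc1/C=C1\Cc2ccccc2C1=O` gives 56500 nM.

Compound 2 stands highest of these two numbers, but its nearest neighbour, compound 1, lies only a 1.2-fold higher number from compound 1 to compound 2 (0.08 log units; within the scatter) away, so the two cannot be told apart. Compound 3 `O=C1/C(=C/c2ccccc2Br)Cc2ccccc21` is not yet measured. Its change from compound 2 is bromo in place of methyl on an aromatic carbon, at the same aromatic carbon where compound 1 carries fluoro and compound 2 carries methyl. Within the data shown here, only one measured step bears on this position: the exchange of fluoro for methyl, which gave a 1.2-fold higher number from compound 1 to compound 2 (0.08 log units; within the scatter), a move within the scatter. A further exchange at this carbon, bromo in place of methyl, is therefore expected to give no step beyond the scatter; the step expected for a 1.1-fold lower number from compound 2 to compound 3 (0.05 log units; within the scatter) is small. For compound 3 the estimate in this assay is 50000 nM, with a plausible range from 20000 nM to 125000 nM.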

Compound 3, half-maximal inhibitory concentration: 46800 nM
Estimate against measurement, compound 3: 1.1-fold (0.03 log units) above, and the stated range covers the measured number.
By their numbers in this assay, from the lowest: compounds 3, 1 and 2 (each within the scatter of the next).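

In this assay, bromo in place of methyl gives a 1.2-fold lower number from compound 2 to compound 3 (0.08 log units; within the scatter), and bromo in place of fluoro gives a 1.0-fold lower number from compound 1 to compound 3 (0.00 log units; within the scatter), so both new steps lie within the scatter. The earlier pair showed only that fluoro and methyl could not be told apart at this aromatic carbon; with bromo as a third group, all three compounds still cannot be told apart, and this carbon shows no preference among these groups. No measured evidence here bears on why these three groups read alike.

Still open, from the compounds shown here alone, is whether a different kind of group at this carbon, such as an amine, a carboxylic acid or a longer chain, would shift the number beyond the scatter. The compounds shown also leave open whether fluoro, methyl and bromo would read alike at other carbons of the same ring.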